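Shifting the Methyl on the Aroyl Group: Compound 3

The source may report more compounds than this note shows. Statements on the series, on what has been measured and on what is new or still open speak of the compounds shown alone.

Measured so far in an ADME assay on HEK-293T cells (Homo sapiens) for cytotoxicity, read by MTT assay, with a stated time of 24 h; a lower number here means that less compound is tolerated, a higher number that more compound is tolerated:
- compound 1, `Cc1cccc(C(=O)n2c(-c3cn(-c4ccccc4)nc3-c3ccc(C(F)(F)F)cc3)nc3ccccc32)c1`, gives 154000 nM
- compound 2, `Cc1ccc(-c2nn(-c3ccccc3)cc2-c2nc3ccccc3n2C(=O)c2cccc(C)c2)cc1`, gives 195000 nM

Compound 1 holds the lowest of the two numbers in this assay; its nearest neighbour is compound 2, and the step of a 1.3-fold higher number from compound 1 to compound 2 (0.10 log units; within the scatter) lies within the scatter. Compound 3, `Cc1ccccc1C(=O)n1c(-c2cn(-c3ccccc3)nc2-c2ccc(C(F)(F)F)cc2)nc2ccccc21`, is the unmeasured partner of compound 1. The change is 2-methylphenyl in place of 3-methylphenyl on a carbonyl carbon. Among the measured compounds shown here, no measured step touches the ring on the carbonyl carbon: the one recorded step, a 1.3-fold higher number from compound 1 to compound 2 (0.10 log units; within the scatter), concerns methyl in place of trifluoromethyl on an aromatic carbon elsewhere in the shared core and stays within the scatter. For the measured compounds named here, with no bearing step and a change that keeps the same atoms joined differently, compound 3 is expected to stay close to compound 1, and the step of a 1.0-fold higher number from compound 1 to compound 3 (0.02 log units; within the scatter) is estimated to lie within the scatter. For compound 3 the expected value in this assay is 160000 nM, with a range from 70000 nM to 350000 nM.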

Compound 3, half-maximal cytotoxic concentration: 179000 nM
Compound 3: the middle estimate sits 1.1-fold (0.05 log units) below what was measured, and the stated range covers the measured number.
By their numbers in this assay, from the lowest: compounds 1, 3 and 2 (each within the scatter of the next).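

Among the compounds shown here, the first step to touch the ring on the carbonyl carbon, 2-methylphenyl in place of 3-methylphenyl, gives a 1.2-fold higher number from compound 1 to compound 3 (0.07 log units; within the scatter) in this assay and so stays within the scatter. For the compounds shown here, until now the only recorded step was methyl in place of trifluoromethyl on an aromatic carbon, and this one shows that the two methylphenyl forms cannot be told apart in this read-out when the rest of compound 1 is kept. Nothing measured here offers an explanation for this result.

The compounds shown leave open whether another group on this ring, such as a methoxy group or a chlorine atom, would also stay within the scatter. They also leave open whether the same change made on compound 2 would give a similar result.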